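Pyridin-2-yl for 3-cyanophenyl on the amidine carbon

The compounds below may be only part of what the source reports. "The series", "measured", "known", "first", "only" and "open" are said of these compounds alone.

Measured so far, in an assay on LM cells for displacement of a labelled ligand from Neuropeptide Y receptor type 5 (Homo sapiens); a lower number here means a stronger inhibitor, a higher number a weaker inhibitor:
compound 1 `Fc1ccc(C2(c3ccc(F)cc3)CNC(c3cccc(C(F)(F)F)c3)=N2)cc1`, 6.2 nM
compound 2 `Fc1ccc(C2(c3ccc(F)cc3)CNC(c3ccc(C(F)(F)F)cc3)=N2)cc1`, 160 nM
compound 3 `N#Cc1cccc(C2=NC(c3ccc(F)cc3)(c3ccc(F)cc3)CN2)c1`, 2.7 nM

Compound 3 gives the lowest number of the three. Its nearest neighbour is compound 1, whose value lies a 2.3-fold lower number from compound 1 to compound 3 (0.36 log units; beyond the scatter) away through cyano in place of trifluoromethyl on an aromatic carbon. Compound 2, which carries the trifluoromethyl on another aromatic carbon, stands far above both on the numbers shown, so the shared core tolerates only certain substitution patterns on this aryl group.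

Compound 4 `Fc1ccc(C2(c3ccc(F)cc3)CNC(c3ccccn3)=N2)cc1` is not yet measured. It differs from compound 3 by pyridin-2-yl in place of 3-cyanophenyl on a carbon with a double bond to nitrogen. Within the data shown here, no measured step covers this exchange: the only single-point step available, a 2.3-fold lower number from compound 1 to compound 3 (0.36 log units; beyond the scatter), concerns a swap of substituents on the aryl ring, not replacement of the whole ring by a smaller heteroaryl ring lacking that substituent. The spread from compound 2 to compound 3 shows that changes on this aryl group can move the number widely.

Working expectation: compound 4 is estimated to be weaker than compound 3, a step of a 7.4-fold higher number from compound 3 to compound 4 (0.87 log units; beyond the scatter), with wide uncertainty. The estimate for compound 4 in this assay is 20 nM, within 5 nM to 80 nM.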

Compound 4, half-maximal inhibitory concentration: 160 nM
Estimate against measurement, compound 4: 8.0-fold (0.90 log units) below; measured number outside the range, above it.
By their numbers in this assay, from the lowest: compound 3; then compound 1; then compounds 2 and 4 (each within the scatter of the next).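

In this assay, the step of a 59-fold higher number from compound 3 to compound 4 (1.77 log units; beyond the scatter) is much larger than the substituent swap a 2.3-fold lower number from compound 1 to compound 3 (0.36 log units; beyond the scatter), so replacing the whole aryl group at this position costs far more than exchanging trifluoromethyl for cyano on the ring. The exchange removes the nitrile, takes the group from 8 heavy atoms to 6 heavy atoms and places a nitrogen in the ring, while the count of hydrogen-bond acceptors stays the same on both sides, so matching that count does not preserve the value, and this single step cannot divide its size among the changes. No data shown here bear on the reason for the loss.

As far as these compounds go, how much of the step belongs to losing the nitrile and how much to the ring nitrogen remains open, and unsubstituted phenyl on the same carbon, together with a pyridine ring that keeps a nitrile, would separate the two. Also open, from the compounds shown here alone, is whether another group on the ring, such as a methoxy or a carboxamide, could recover the value of compound 3 at 2.7 nM in this assay on a pyridine ring.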